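The source may hold more compounds than are shown below. What is called first, only, known or untested is meant among the compounds shown, and "the series" means these compounds.

In a functional assay on MCF7 cells (Homo sapiens) for antiproliferative activity, read by MTT assay, with a stated time of 48 h (a lower number here means a stronger inhibitor, a higher number a weaker inhibitor), three related compounds have been measured so far. Compound 2 `COc1ccc(C(=O)c2ccc(OC)c3c2OC(C)(C)C=C3)c(NC(=O)CO)c1` gives 320 nM. Compound 3 `COc1ccc(C(=O)c2ccc3c(c2)C=CC(C)(C)O3)c(NC(=O)CO)c1` gives 200 nM, which is within the usual scatter of the value for compound 2, so the two cannot be told apart. Compound 1 `COc1ccc(C(=O)c2ccc(OC)c3c2C=CC(C)(C)O3)c(NC(=O)CBr)c1` gives 3290 nM, a higher number by a margin well beyond the scatter. Compound 2 therefore stands level with compound 3, at the stronger end of this small set.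

Compound 4 `CCNCC(=O)Nc1cc(OC)ccc1C(=O)c1ccc(OC)c2c1OC(C)(C)C=C2` keeps the rest of compound 2 and changes one group: ethylamino in place of hydroxy on a saturated chain carbon bound to a carbonyl carbon. Among the compounds with values here, no measured pair differs in one place only, so no measured step shows the size of this change directly. Compound 1 carries a different group on that chain, but its core differs as well, so its 3290 nM cannot be read as the effect of that group alone. With so little to go on, the likeliest outcome in this assay is no step beyond the scatter, with a slight lean towards a higher number. The expected change is a 1.6-fold higher number from compound 2 to compound 4 (0.19 log units; within the scatter). For compound 4 the estimated value is 500 nM, with an expected range from 130 nM to 1900 nM.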

Compound 4, half-maximal inhibitory concentration: 5200 nM
For compound 4 the middle estimate is 10-fold (1.02 log units) below the measured one, outside the stated range (above it).
By their numbers in this assay, from the lowest: compounds 3 and 2 (each within the scatter of the next); then compounds 1 and 4 (each within the scatter of the next).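

In this assay, within the data shown here, this is the first direct reading of what the group on this saturated chain carbon can do: with the rest of compound 2 unchanged, swapping hydroxy for ethylamino gives a 16-fold higher number from compound 2 to compound 4 (1.21 log units; beyond the scatter), a large step well beyond the scatter. So this position is not indifferent to what it carries, and the earlier compounds could not show that, since no two of them differed in one place only. The step also arises although hydroxy and ethylamino have equal counts of hydrogen-bond donors and acceptors and neither has a net charge, so those counts alone do not separate the two groups, and no measurement shown here explains the step.

Still open, as far as these compounds go, is whether the nitrogen or the added carbons of ethylamino matter more: a plain amino group on the same chain carbon and a longer chain ending in hydroxy would help to tell these apart. From the compounds shown here alone, this is also a single pair on one core, so whether the same change has a similar effect on the core of compound 3 remains unknown.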